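Trimming the amide acyl group on a shared core

A few compounds are considered here, and "the series" means these few. Any claim that something is new, unique, unknown or untested is made for them only; others in the source may bear on it.

Compound 1 `COc1ncc(N2CCc3ncnc(O[C@H]4CCN(C(=O)C5CCOCC5)C4)c3C2)cc1C(F)(F)F` is the higher of the two measured compounds in an ADME assay on microsomes from liver (Rattus norvegicus) for metabolic stability; on this read-out lower numbers stand for slow clearance and higher numbers for fast clearance: compound 1 gives 149 uL/min, while compound 2 `COc1ncc(N2CCc3ncnc(O[C@H]4CCN(C(=O)C5CCOCC5)C4)c3C2)cc1C` gives 60 uL/min, and the measured step of a 2.5-fold lower number from compound 1 to compound 2 (0.40 log units; beyond the scatter) is a methyl in place of trifluoromethyl on an aromatic carbon. Compound 3 `CCC(=O)N1CC[C@H](Oc2ncnc3c2CN(c2cnc(OC)c(C(F)(F)F)c2)CC3)C1` differs from compound 1 elsewhere: ethyl in place of oxan-4-yl on a carbonyl carbon, which read one bond further out is (oxan-4-yl)carbonyl to propanoyl. Within the data shown here, no measured step touches this carbonyl carbon, so the only measured step, from compound 1 to compound 2, gives no direct guidance on the size or direction of the change in this assay. With nothing to lean on, compound 3 is expected to stay close to compound 1, a step of a 1.0-fold higher number from compound 1 to compound 3 (0.00 log units; within the scatter) that does not clearly exceed the scatter. Compound 3 is therefore estimated at 150 uL/min in this assay, within a range from 70 uL/min to 320 uL/min.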

Compound 3, intrinsic clearance in a liver preparation (reported as CLH), per the amount of preparation that the assay uses: 160 uL/min
Compound 3: the middle estimate sits 1.1-fold (0.03 log units) below what was measured; the measured number falls inside the stated range.
By their numbers in this assay, from the lowest: compound 2; then compounds 1 and 3 (each within the scatter of the next).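

In this assay, among these compounds, the new step, a 1.1-fold higher number from compound 1 to compound 3 (0.03 log units; within the scatter), is the first reading at this carbonyl carbon, and it shows that oxan-4-yl can give way to ethyl without a change beyond the scatter. The six-membered ring and its oxygen can therefore leave this position with the number holding, whereas the step on the aromatic carbon, a 2.5-fold lower number from compound 1 to compound 2 (0.40 log units; beyond the scatter), does lie beyond the scatter. Nothing shown explains why the number holds at the carbonyl carbon. From the compounds shown here alone, it remains open whether ethyl would behave the same way in the methyl series of compound 2, where the starting number is lower. Going by these compounds, it is also open whether a longer chain, an amine or a carboxylic acid on this carbonyl carbon would move the number.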